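Replacing the carboxyethyl pyrazole group of compound 1

The source may report more compounds than this note shows. Statements on the series, on what has been measured and on what is new or still open speak of the compounds shown alone.

Within the data shown here, in a functional assay on MCF7 cells (Homo sapiens) for antiproliferative activity, read by sulforhodamine B assay, with a stated time of 72 h (a lower number here means a stronger inhibitor, a higher number a weaker inhibitor), compound 1 `COc1ncc(-c2ccc3ncnc(Nc4cnn(CCC(=O)O)c4)c3c2)cc1NS(C)(=O)=O` gives 560 nM, the lowest of the three numbers so far. Compound 2 `COc1ncc(-c2ccc3ncnc(Nc4ccc(OCCO)nc4)c3c2)cc1NS(=O)(=O)c1ccc(F)cc1F` gives 4300 nM, and compound 3 `COc1cc(Nc2ncnc3ccc(-c4cnc(OC)c(NS(=O)(=O)c5ccc(F)cc5F)c4)cc23)ccc1OCCO` gives 2260 nM. Compound 4 `COc1ncc(-c2ccc3ncnc(Nc4ccc(OCCO)cc4)c3c2)cc1NS(C)(=O)=O`, not yet measured, carries 4-(2-hydroxyethoxy)phenyl in place of 1-(2-carboxyethyl)-1H-pyrazol-4-yl on a nitrogen on an aromatic ring. One measured step changes a group at this place, a 1.9-fold lower number from compound 2 to compound 3 (0.28 log units; within the scatter), and it stays within the scatter. Compounds 2 and 3 also differ from compound 4 in their sulfonamide, so they guide only loosely. The estimated change is a 1.4-fold higher number from compound 1 to compound 4 (0.15 log units; within the scatter), a small rise that is expected to stay within the scatter. Compound 4 is expected at 800 nM, with an estimated range of 200 nM to 3000 nM.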

Compound 4, half-maximal inhibitory concentration: 3270 nM
Compound 4: middle estimate off by 4.1-fold (0.61 log units), on the low side; the measured number lies above the stated range.
By their numbers in this assay, from the lowest: compound 1; then compounds 3, 4 and 2 (each within the scatter of the next).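

In this assay, the change at this place gives a 5.8-fold higher number from compound 1 to compound 4 (0.77 log units; beyond the scatter), whereas the earlier step at this place, a 1.9-fold lower number from compound 2 to compound 3 (0.28 log units; within the scatter), showed no clear effect. So this place can respond to a change of group, although the ring and the end of the chain change together in this step. No measurement shown here explains the rise. Still open, on these data alone, is whether the ring or the chain end accounts for it. A 1-(2-hydroxyethyl)-1H-pyrazol-4-yl group or a 4-(2-carboxyethyl)phenyl group would separate the two.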